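The source may hold more compounds than are shown below. What is called first, only, known or untested is meant among the compounds shown, and "the series" means these compounds.

Measured so far:

- compound 1, `O=C(Nc1cc(Oc2ccc(Nc3nccc4[nH]cc(-c5ccc(F)cc5)c(=O)c34)cc2F)ccn1)C1CCC1`: 52.8%
- compound 2, `CCn1cc(-c2ccc(F)cc2)c(=O)c2c(Nc3ccc(Oc4ccnc(NC(=O)C5CC5)c4)c(F)c3)nccc21`: 31.9%

Among the compounds with values here, compound 1 carries the higher of the two numbers in a functional assay on MKN-45 cells (Homo sapiens) for antiproliferative activity, read by MTT assay, with a stated time of 72 h, tested at 10 uM; on this read-out higher numbers stand for more inhibition at the one concentration tested (going by the name of the read-out) and lower numbers for less inhibition; compound 2 sits lower by a gap beyond the usual scatter, so the two are distinguishable on this read-out, though only two compounds have been measured and nothing more general can be drawn from them.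

Compound 3, `CC(=O)Nc1cc(Oc2ccc(Nc3nccc4[nH]cc(-c5ccc(F)cc5)c(=O)c34)cc2F)ccn1`, has not been measured. It differs from compound 1 in one place: methyl in place of cyclobutyl on a carbonyl carbon. Within the data shown here, no measured pair shows the effect of this change, so the expected step rests only on the single measured value of compound 1. A small step downward is expected, a number 8.8 percentage points lower from compound 1 to compound 3 (within the scatter), with a range wide enough to include no change beyond the scatter. Compound 3 is thus estimated at 44%, in the range from 26% to 62%.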

Compound 3, a percentage reported as inhibition, at one concentration (the size of the read-out at that concentration, not a potency): 77.1%
Compound 3: the middle estimate sits 33.1 percentage points below what was measured, outside the stated range (above it).
By their numbers in this assay, from the lowest: compound 2; then compound 1; then compound 3.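

Within the data shown here, the carbonyl carbon on the amide-type nitrogen is the first place where a single change can be read: in this assay, methyl in place of cyclobutyl gives a number 24.3 percentage points higher from compound 1 to compound 3 (beyond the scatter). The group at this position therefore matters on this read-out, and the four-membered ring of compound 1 is not required for inhibition at the one concentration tested, since compound 3 lacks it. Nothing measured here accounts for the step.

On these data alone, a single pair gives two points only, so it remains open whether ethyl, a longer chain such as n-butyl, or an amine such as dimethylamino on the same carbonyl carbon would follow the same direction. As far as these compounds go, whether the step would carry over to the N-ethyl core of compound 2 also remains open.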